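Adding Chloro to the Anilino Ring in Two Cores

The source may report more compounds than this note shows. Statements on the series, on what has been measured and on what is new or still open speak of the compounds shown alone.

Compound 1 `CC(C)c1ccc2c(CCCCS(=O)(=O)Nc3ccccc3)cc(C(=O)O)c-2cc1` carries a carboxylic acid on its core and a chain ending in a sulfonamide on a plain phenyl ring. In a functional assay on thoracic aorta for antagonist activity at thromboxane A2 receptor (Rattus norvegicus) (a higher number here means a weaker inhibitor, a lower number a stronger inhibitor), compound 1 gives 8700 nM. Compound 2 `CC(C)c1ccc2c(CCCCS(=O)(=O)Nc3ccc(Cl)cc3)cc(C(=O)O)c-2cc1` differs from it only by chloro in place of hydrogen on an aromatic carbon, and in this assay compound 2 gives 2600 nM, which is a 3.3-fold lower number from compound 1 to compound 2 (0.52 log units; beyond the scatter).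

Compound 3 `CC(C)c1ccc2c(CCCS(=O)(=O)Nc3ccccc3)cc(S(=O)(=O)O)c-2cc1` belongs to a second core; the difference between the two cores is not broken down here. In this assay compound 3 gives 8700 nM, level with compound 1 at the digits reported. Compound 4 `CC(C)c1ccc2c(CCCS(=O)(=O)Nc3ccc(Cl)cc3)cc(S(=O)(=O)O)c-2cc1` differs from compound 3 by chloro in place of hydrogen on an aromatic carbon, the same change at the same place that turned compound 1 into compound 2.

Within the data shown here, only one measured example of this change exists, so the expectation for the second core rests on it alone. For compound 4 a step of a 3.1-fold lower number from compound 3 to compound 4 (0.49 log units; beyond the scatter) is expected, taken from compound 2 and its step of a 3.3-fold lower number from compound 1 to compound 2 (0.52 log units; beyond the scatter). Compound 4 is therefore estimated at 2800 nM, most likely between 1200 nM and 6500 nM.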

Compound 4, half-maximal inhibitory concentration: 860 nM
Estimate against measurement, compound 4: 3.3-fold (0.51 log units) above; measured number outside the range, below it.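

In this assay, chloro in place of hydrogen also lowers the number on the second core, with a 10-fold lower number from compound 3 to compound 4 (1.01 log units; beyond the scatter), so the direction of the change carries over from one core to the other in these two pairs. The size of the step does not carry over, as the two measured steps show: the same change on two cores in this assay, a 3.3-fold lower number (0.52 log units; beyond the scatter) from compound 1 to compound 2 and a 10-fold lower number (1.01 log units; beyond the scatter) from compound 3 to compound 4, 3.0-fold (0.48 log units) apart, beyond the scatter of two such steps This means that the gain from the same chloro depends on the core it sits on, but two pairs cannot show which feature of the core is responsible or how the change would behave on any further core.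

Going by these compounds, the two cores differ in both the acid and the chain, so it remains open whether the larger step goes with the sulfonic acid in place of the carboxylic acid or with the difference in the chain. Also open, on these data alone, is whether another group on the anilino ring, such as bromo or methoxy, would give steps that differ between the two cores in the same way.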